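Amide substituent changes on the shared core in rat paw edema

The source may hold more compounds than are shown below. What is called first, only, known or untested is meant among the compounds shown, and "the series" means these compounds.

Three amides on the same core have numbers in a functional assay on the whole organism for inhibition, with Rattus norvegicus as the target, read by cytopathic effect and paw edema, at a dose of 100 mg/kg by the oral route; a lower number here means less inhibition, a higher number more inhibition at the dose given (going by the name of the read-out). Compound 1 `O=C(NCc1ccccc1)c1c(O)c2cccnc2n(-c2ccccc2)c1=O` gives 11.3% in this assay. Compound 2 `O=C(Nc1ccc(Cl)cc1)c1c(O)c2cccnc2n(-c2ccccc2)c1=O` gives 2.5%. Compound 3 `O=C(Nc1cccc([N+](=O)[O-])c1)c1c(O)c2cccnc2n(-c2ccccc2)c1=O` gives 7.4%. The three numbers sit within the usual scatter of one another: the step of a number 8.8 percentage points lower from compound 1 to compound 2 (within the scatter), the step of a number 3.9 percentage points lower from compound 1 to compound 3 (within the scatter) and the step of a number 4.9 percentage points higher from compound 2 to compound 3 (within the scatter) all fall inside it. On the raw numbers compound 3 has compound 1 as its nearest neighbour and compound 2 as its furthest, and neither gap counts as a real difference.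

Compound 4 `COc1ccccc1NC(=O)c1c(O)c2cccnc2n(-c2ccccc2)c1=O` is not yet measured. It differs from compound 3 in one place: 2-methoxyphenyl in place of 3-nitrophenyl on an amide-type nitrogen. Every measured step in the series is of the same kind, a swap of the group on the amide-type nitrogen whose other neighbour is the carbonyl carbon, and none of them moved the read-out beyond the scatter. Among the compounds with values here, no measured pair speaks for a 2-methoxyphenyl group in particular, so the expectation rests only on the flatness seen so far. The estimated step is a number 0.4 percentage points lower from compound 3 to compound 4 (within the scatter), with no direction expected beyond the scatter. Compound 4 is therefore expected to give about 7% in this assay, in the range 0% to 18%.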

Compound 4, a percentage reported as inhibition, in the whole organism at one dose (the size of the read-out at that dose, not a potency): -10.1%
Compound 4: the middle estimate sits 17.1 percentage points above what was measured; measured number below the stated range.
By their numbers in this assay, from the lowest: compound 4; then compounds 2, 3 and 1 (each within the scatter of the next).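

The group on the amide-type nitrogen is not a silent place in this assay: with 2-methoxyphenyl the read-out separates from all three earlier groups, giving a number 17.5 percentage points lower from compound 3 to compound 4 (beyond the scatter) and a number 12.6 percentage points lower from compound 2 to compound 4 (beyond the scatter) and also a number 21.4 percentage points lower from compound 1 to compound 4 (beyond the scatter), whereas benzyl, 4-chlorophenyl and 3-nitrophenyl stayed within the scatter of one another. Within the data shown here, compound 4 is therefore the only compound set apart from the rest, and with compound 4 at -10.1% the change carries the number below zero, not merely to a smaller inhibition. Nothing available bears on why this one swap moves the read-out when the others did not.

The compounds shown do not separate the methoxy group itself from its placement on the ring, and 3-methoxyphenyl and 4-methoxyphenyl on the same nitrogen would address that directly. Also open, on these data alone, is whether the step belongs to methoxy alone or extends to other groups in the same placement, such as 2-chlorophenyl, 2-methylphenyl or 2-hydroxyphenyl, and whether a number below zero holds up on repeat at this single dose.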